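A few compounds are considered here, and "the series" means these few. Any claim that something is new, unique, unknown or untested is made for them only; others in the source may bear on it.

Measured in a functional assay with Homo sapiens as the target; a lower number here means a stronger inhibitor, a higher number a weaker inhibitor:
compound 1 `CC(C)[C@H](NC(=O)COc1cccc2ccccc12)C(=O)N[C@@H](CC(=O)O)C(=O)COc1cccc(C(F)(F)F)c1`: 16600 nM
compound 2 `CC(C)[C@H](NC(=O)COc1cccc2ccccc12)C(=O)N[C@@H](CC(=O)O)C(=O)COc1ccc(C(F)(F)F)cc1`: 12300 nM
compound 3 `CC(C)[C@H](NC(=O)COc1cccc2ccccc12)C(=O)N[C@@H](CC(=O)O)C(=O)COc1ccc([N+](=O)[O-])cc1`: 22800 nM

In this assay, compound 3 gives 22800 nM, which lies within the scatter of both other compounds: the steps are a 1.4-fold higher number from compound 1 to compound 3 (0.14 log units; within the scatter) and a 1.9-fold higher number from compound 2 to compound 3 (0.27 log units; within the scatter). The next compound, compound 4 `CC(C)[C@H](NC(=O)COc1cccc2ccccc12)C(=O)N[C@@H](CC(=O)O)C(=O)COc1ccc(F)c(F)c1`, has 3,4-difluorophenyl in place of 4-nitrophenyl on an oxygen on a saturated carbon. Among the measured compounds shown here, no measured compound carries this group, so the evidence is indirect. For the measured compounds named here, three steps bear on the change, all of them swaps of the same aryl group. Alongside the two above, the third is a 1.3-fold lower number from compound 1 to compound 2 (0.13 log units; within the scatter). Going by the values given here, since none of these steps leaves the scatter, the series so far shows no response to the swaps tried, and no step beyond the scatter is expected for the new swap, in either direction. The estimated step is a 1.4-fold lower number from compound 3 to compound 4 (0.15 log units; within the scatter). For compound 4 the expected value is 16000 nM, with an estimated range from 8000 nM to 32000 nM.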

Compound 4, half-maximal inhibitory concentration: 16200 nM
Compound 4: middle estimate off by 1.0-fold (0.01 log units), on the low side; the measured number falls inside the stated range.
By their numbers in this assay, from the lowest: compounds 2, 4, 1 and 3 (each within the scatter of the next).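

In this assay, among the compounds shown here, 3,4-difluorophenyl is the first group at this place with two ring substituents, and it too leaves the number within the scatter: the steps are a 1.4-fold lower number from compound 3 to compound 4 (0.15 log units; within the scatter) and a 1.3-fold higher number from compound 2 to compound 4 (0.12 log units; within the scatter) as well as a 1.0-fold lower number from compound 1 to compound 4 (0.01 log units; within the scatter) in this assay. The flat response on the oxygen on a saturated carbon therefore now spans four aryl groups, and it holds for a ring carrying only fluorine as well as for those carrying trifluoromethyl or nitro. No measurement here offers an explanation for this lack of response.

The compounds shown leave open whether a ring bearing an amine or a carboxylic acid would move the number beyond the scatter. They also leave open whether a longer chain in place of (3,4-difluorophenoxy)methyl, or a change elsewhere in the shared core, would do so.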